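Shifting fluorines on the aryl group: compound 3 to compound 4

The source may hold more compounds than are shown below. What is called first, only, known or untested is meant among the compounds shown, and "the series" means these compounds.

Three measured compounds share one core and differ only in the difluoro-methoxyphenyl group carried on the saturated ring carbon. Compound 1 `COc1c(C2CCN(c3ccn4c(CC5CC5)nnc4c3Cl)CC2)ccc(F)c1F` gives 26 nM in a functional assay on CHO cells for agonist activity at metabotropic glutamate receptor 2 (Homo sapiens), read by scintillation counting and GTPgammaS binding, with a stated time of 30 min; on this read-out lower numbers stand for an effect already at smaller amounts and higher numbers for an effect only at larger amounts of compound. Compound 2 `COc1c(F)ccc(F)c1C1CCN(c2ccn3c(CC4CC4)nnc3c2Cl)CC1` gives 7.5 nM in this assay, and compound 3 `COc1ccc(F)c(F)c1C1CCN(c2ccn3c(CC4CC4)nnc3c2Cl)CC1` gives 9.3 nM. Compound 3 thus stands second highest of the three numbers: its nearest neighbour is compound 2, which lies within the scatter of it, while the step of a 2.8-fold lower number from compound 1 to compound 3 (0.45 log units; beyond the scatter) lies beyond the scatter. Compound 4 `COc1cc(F)cc(F)c1C1CCN(c2ccn3c(CC4CC4)nnc3c2Cl)CC1` has not yet been measured. The change is 2,4-difluoro-6-methoxyphenyl in place of 2,3-difluoro-6-methoxyphenyl on a saturated ring carbon. Among the measured compounds shown here, two measured steps concern a rearrangement of the two fluorines on the methoxyphenyl group: a 3.5-fold lower number from compound 1 to compound 2 (0.54 log units; beyond the scatter) and a 2.8-fold lower number from compound 1 to compound 3 (0.45 log units; beyond the scatter), both modest, whereas a 1.2-fold higher number from compound 2 to compound 3 (0.09 log units; within the scatter) stays within the scatter. Moving fluorines within this group has so far shifted the number by a modest amount at most, and in one case not at all beyond the scatter. For compound 4 the step of a 1.2-fold higher number from compound 3 to compound 4 (0.07 log units; within the scatter) is therefore expected to be small, possible in either direction and most likely within the scatter. Compound 4 is estimated at 11 nM in this assay, with a range from 4 nM to 30 nM.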

Compound 4, half-maximal effective concentration: 6.9 nM
For compound 4 the middle estimate is 1.6-fold (0.20 log units) above the measured one, and the stated range covers the measured number.
By their numbers in this assay, from the lowest: compounds 4, 2 and 3 (each within the scatter of the next); then compound 1.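

In this assay the 2,4-difluoro-6-methoxyphenyl group on the saturated ring carbon adds a third arrangement to the cluster: the steps of a 1.3-fold lower number from compound 3 to compound 4 (0.13 log units; within the scatter) and a 1.1-fold lower number from compound 2 to compound 4 (0.04 log units; within the scatter) are both within the scatter, so compounds 2, 3 and 4 cannot be told apart on this read-out, and this position tolerates all three placements of the two fluorines. The 3,4-difluoro-2-methoxyphenyl group of compound 1 remains the only arrangement set apart, and the step of a 3.8-fold lower number from compound 1 to compound 4 (0.58 log units; beyond the scatter) confirms that separation with a third modest step beyond the scatter, making compound 1 the single exception among the four compounds. Nothing at hand accounts for why compound 1 alone stands apart.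

On these data alone, all four compounds carry one methoxy group and two fluorines on the phenyl ring, so the response to a nitrile or a trifluoromethyl group in place of a fluorine, or to an ethoxy group in place of the methoxy, remains open. Also open, as far as these compounds go, is whether these fluorine arrangements would still read alike with an amine in place of the chlorine on the shared core.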